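Compound 4: a Methylthiophene in Place of a Pyrrole

The source may hold more compounds than are shown below. What is called first, only, known or untested is meant among the compounds shown, and "the series" means these compounds.

Measured so far in an ADME assay on Vero cells (Chlorocebus sabaeus) for cytotoxicity, read by MTT assay, with a stated time of 72 h; a lower number here means a stronger inhibitor, a higher number a weaker inhibitor:
- compound 1 `O=[N+]([O-])c1c[nH]c(-c2nnc(-c3ccc[nH]3)o2)c1`: 227000 nM
- compound 2 `Cn1cc([N+](=O)[O-])cc1-c1nnc(-c2cccc([N+](=O)[O-])c2O)o1`: 269000 nM
- compound 3 `O=[N+]([O-])c1c[nH]c(-c2nnc(-c3cccc([N+](=O)[O-])c3O)o2)c1`: 499000 nM

Compound 1 gives the lowest of the three numbers. Compound 2 sits nearest to it, a gap that lies within the scatter, while compound 3 lies furthest, a gap beyond the scatter. For the measured compounds named here, only one step between two compounds that differ in a single place has been measured, a 1.9-fold higher number from compound 2 to compound 3 (0.27 log units; within the scatter), and it concerns hydrogen in place of methyl on an aromatic nitrogen, a change that does not involve the part of the molecule altered here.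

Compound 4 `Cc1ccc(-c2nnc(-c3cc([N+](=O)[O-])c[nH]3)o2)s1` has not yet been measured. It differs from compound 1 in one place: 5-methylthiophen-2-yl in place of 1H-pyrrol-2-yl on an aromatic carbon. Going by the values given here, no measured pair shows this exchange, so there is no direct step to lean on; what is known is that all three measured numbers in this assay lie close together. On that basis a step of no size beyond the scatter is expected. Compound 4 is therefore expected to give about 250000 nM, between 100000 nM and 600000 nM, which amounts to an estimated step of a 1.1-fold higher number from compound 1 to compound 4 (0.04 log units; within the scatter).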

Compound 4, half-maximal inhibitory concentration: 329000 nM
For compound 4 the middle estimate is 1.3-fold (0.12 log units) below the measured one, within the range that was stated.
By their numbers in this assay, from the lowest: compounds 1, 2, 4 and 3 (each within the scatter of the next, the first and the last beyond it).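

In this assay, 5-methylthiophen-2-yl in place of 1H-pyrrol-2-yl gives a 1.4-fold higher number from compound 1 to compound 4 (0.16 log units; within the scatter), so the two compounds cannot be told apart here. For the compounds shown here, this is the first view of this position, since the only earlier step concerned hydrogen in place of methyl on an aromatic nitrogen, and it shows that the number can stay within the scatter even though the entering group has no hydrogen-bond donor and the leaving group has one. No measurement at hand speaks to the reason for this result.

As far as these compounds go, whether an amine or a carboxylic acid at this position would leave the number just as undisturbed remains open. So does the separate contribution of the methyl, which a plain thiophen-2-yl group could isolate from that of the ring exchange.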